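A few compounds are considered here, and "the series" means these few. Any claim that something is new, unique, unknown or untested is made for them only; others in the source may bear on it.

Among the compounds with values here, compound 1 `NS(=O)(=O)c1ccc(C(=O)NNC(=O)c2ccc(Cl)c(Cl)c2)cc1` is one of two compounds measured in an assay on cells for inhibition of Amine oxidase [flavin-containing] B (Homo sapiens), read by fluorescence and spectrophotometry, using microsomes, with a stated time of 20 min (a lower number here means a stronger inhibitor, a higher number a weaker inhibitor), and in that assay compound 1 gives 10100 nM, the higher of the two numbers recorded. Within the data shown here, the other measured compound, compound 2 `Cc1ccc(-c2nnc(-c3cccc(S(N)(=O)=O)c3)o2)cc1`, is built on a different framework, and in this assay compound 2 gives 571 nM; the two values are far apart, with compound 1 the weaker inhibitor by a margin well beyond the scatter, and no single-change step links them.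

Compound 3 `NS(=O)(=O)c1ccc(C(=O)NNC(=O)c2ccc(Cl)cc2)cc1` keeps the core of compound 1 and differs from it in one place: hydrogen in place of chloro on an aromatic carbon. Among the measured compounds shown here, no measured pair shows what removing a chloro group from this ring does here, so the expectation can rest only on the change itself and on the value of compound 1. Removing one heavy atom from the dichlorophenyl ring is a small change, and compound 3 is expected to be a somewhat weaker inhibitor than compound 1, with a step from compound 1 to compound 3 of about a 1.6-fold higher number from compound 1 to compound 3 (0.20 log units; within the scatter) that may still sit within the scatter. In this assay compound 3 is therefore estimated at 16000 nM, with a plausible range from 5000 nM to 50000 nM.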

Compound 3, half-maximal inhibitory concentration: 11700 nM
The estimate for compound 3 lay 1.4-fold (0.14 log units) above the measured number; low and high end bracket the measured number.
By their numbers in this assay, from the lowest: compound 2; then compounds 1 and 3 (each within the scatter of the next).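

In this assay, putting hydrogen in place of chloro on this aromatic carbon, which turns the 3,4-dichlorophenyl group into a 4-chlorophenyl group, gives a 1.2-fold higher number from compound 1 to compound 3 (0.06 log units; within the scatter) and so leaves the number effectively unmoved. Within the data shown here, this is the first measured pair that isolates a single change on this ring, and it shows that, in this series, the assay does not distinguish between chloro and hydrogen at this place, so this chloro group is not needed to keep the activity at the level seen for compound 1. Nothing available here explains why the exchange makes so little difference.

The compounds shown leave open whether the chloro group that remains in compound 3 is equally dispensable, which a plain phenyl group on the same core would test. They also leave open whether a group such as methoxy, an amine or a carboxylic acid on this aromatic carbon would move the number beyond the scatter, since chloro and hydrogen are the only two substituents compared here.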